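The source may report more compounds than this note shows. Statements on the series, on what has been measured and on what is new or still open speak of the compounds shown alone.

Of the compounds shown here, three have so far been measured in a physicochemical assay for solubility, measured as kinetic solubility, with a stated time of 1 h, at pH 7.4; on this read-out higher numbers stand for higher solubility and lower numbers for lower solubility. Compound 1 `CC(=O)Nc1nc(-c2cccc(O)c2)cs1` gives 103000 nM, compound 2 `N#CCC(=O)Nc1csc(-c2ccc(Cl)c(Cl)c2)c1` gives 10000 nM, and compound 3 `N#CCC(=O)NC1=NN(c2ccc(Cl)c(Cl)c2)CC1` gives 202000 nM. Compound 3 therefore holds the highest of the three numbers, but its gap to compound 1 lies within the usual scatter, so those two cannot be ranked against each other; only compound 2 sits clearly lower than compound 3.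

The next compound, compound 4 `O=C(NC1=NN(c2ccc(Cl)c(Cl)c2)CC1)c1ccncc1F`, keeps the core of compound 3 and changes one thing:

3-fluoropyridin-4-yl in place of cyanomethyl on a carbonyl carbon

Within the data shown here, no pair of measured compounds differs in a single place, so there is no measured step of this kind to lean on. The change swaps a short chain for a larger aromatic ring, and on the basis of the three numbers alone a moderate downward step in this assay is expected, of the size a 3.4-fold lower number from compound 3 to compound 4 (0.53 log units; beyond the scatter), somewhat beyond the scatter. Compound 4 is thus estimated to give 60000 nM, with a likely range from 20000 nM to 180000 nM.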

Compound 4, solubility: 36000 nM
Estimate against measurement, compound 4: 1.7-fold (0.22 log units) above; measured number inside the range.
By their numbers in this assay, from the lowest: compound 2; then compound 4; then compounds 1 and 3 (each within the scatter of the next).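

On the carbonyl carbon of the shared core, 3-fluoropyridin-4-yl in place of cyanomethyl gives a measured change in this assay: a 5.6-fold lower number from compound 3 to compound 4 (0.75 log units; beyond the scatter). Among these compounds, this is the first single-place comparison in the set, and it shows that the number at this position depends on the group placed there, with compound 4 still reading 36000 nM with the aromatic ring attached. No available measurement accounts for the size or direction of this step, so it stands as an observation without an explanation.

On these data alone, one step cannot separate the contributions of the ring, its nitrogen and its fluorine, so it remains open how a plain phenyl or an unfluorinated pyridin-4-yl would compare at this carbonyl carbon. As far as these compounds go, it is also open whether a dimethylaminomethyl group or a longer chain ending in a carboxylic acid would raise or lower the number there.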